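The compounds below may be only part of what the source reports. "The series", "measured", "known", "first", "only" and "open" are said of these compounds alone.

Four nucleoside analogues share a sugar on a fused core. Compound 1 `COc1ncnc2c1c(-c1ccsc1)cn2[C@@H]1O[C@H](CO)[C@@H](O)[C@H]1O` is the reference point. In a functional assay on A549 cells (Homo sapiens), read by MTT assay, with a stated time of 72 h (on this read-out lower numbers stand for stronger inhibition and higher numbers for weaker inhibition), compound 1 gives 5170 nM. Compound 2 `COc1nc(N)nc2c1c(-c1ccsc1)cn2[C@@H]1O[C@H](CO)[C@@H](O)[C@H]1O` differs from compound 1 by amino in place of hydrogen on an aromatic carbon. In this assay compound 2 reaches only a limit, > 100000 nM. The change brought an at least 19-fold higher number from compound 1 to compound 2 (1.28 log units; beyond the scatter), and the reading of this step is shaped by the limit of > 100000 nM in this assay, at which 2 of the 3 values shown sit.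

Compound 3 `O=c1[nH]cnc2c1c(-c1ccccc1)cn2[C@@H]1O[C@H](CO)[C@@H](O)[C@H]1O` carries a different core; the difference between the core of compound 1 and the core of compound 3 is not broken down here. In this assay compound 3 also reaches only a limit, > 100000 nM.

Compound 4 `Nc1nc2c(c(-c3ccccc3)cn2[C@@H]2O[C@H](CO)[C@@H](O)[C@H]2O)c(=O)[nH]1` has not yet been measured. It differs from compound 3 by amino in place of hydrogen on an aromatic carbon. This is the same kind of change as that from compound 1 to compound 2, though the surroundings differ: in compound 2 the entering amino is meta to a methoxy group (2 heavy atoms), whereas in compound 4 it is meta to a group of 1 heavy atom.

Since the same kind of change weakened compound 2 relative to compound 1 by an at least 19-fold higher number from compound 1 to compound 2 (1.28 log units; beyond the scatter), and since compound 3 already sits at the limit, compound 4 is expected to remain at or beyond that limit, an expected step that the limit leaves unreadable from compound 3 to compound 4. Compound 4 is therefore estimated at about 300000 nM, most likely again reported only as a limit.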

Compound 4, half-maximal inhibitory concentration: > 100000 nM
Compound 4 ended at the assay's limit; the forecaster's own chance of this, stated with the estimate: 90%; the middle value does not contradict the limit.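

Compound 3 and compound 4 both stand only at a limit, so no step can be read from the one to the other: the limit of > 100000 nM in this assay, at which 3 of the 4 values shown sit.

The compounds shown leave open whether amino in place of hydrogen on an aromatic carbon changes the inhibition at all on the core of compound 3, and how far past the limit either compound lies.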